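The source may hold more compounds than are shown below. What is called first, only, known or untested is meant among the compounds shown, and "the series" means these compounds.

Values in an ADME assay on MT4 cells (Homo sapiens) for cytotoxicity, with a stated time of 5 days; on this read-out lower numbers stand for higher toxicity in this test and higher numbers for lower toxicity in this test:
- compound 1 `O=C(CCl)Nc1ccc(Cl)cc1NS(=O)(=O)c1c(F)cccc1F`: 175000 nM
- compound 2 `O=c1[nH]c2ccc(Cl)cc2n1S(=O)(=O)c1cc(Cl)cc(Cl)c1`: 179000 nM
- compound 3 `O=C1CN(S(=O)(=O)c2cc(Cl)cc(Cl)c2)c2cc(Cl)ccc2N1`: >= 205000 nM (a limit)
- compound 4 `Cc1cc(C)cc(S(=O)(=O)Nc2cc(Cl)ccc2NC(=O)CCl)c1`: not yet measured

Compound 1, at 175000 nM, lies within the usual scatter of compound 2, at 179000 nM. Compound 3 gives >= 205000 nM, which is a limit of the assay and not a number.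

Compound 4 differs from compound 1 by one change: 3,5-dimethylphenyl in place of 2,6-difluorophenyl on a sulfonyl sulfur. Among the measured compounds shown here, no step between measured compounds shows what such a swap does, so no shift beyond the scatter is expected in this assay. The expected size of the change is a 1.1-fold lower number from compound 1 to compound 4 (0.04 log units; within the scatter). Compound 4 is estimated at 160000 nM, with an expected range from 70000 nM to 240000 nM.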

Compound 4, half-maximal cytotoxic concentration: 35100 nM
Estimate against measurement, compound 4: 4.6-fold (0.66 log units) above; the whole stated range lies above it.
By their numbers in this assay, from the lowest: compound 4; then compounds 1 and 2 (each within the scatter of the next). At a limit, above all of these: compound 3.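

In this assay the change to 3,5-dimethylphenyl in place of 2,6-difluorophenyl on a sulfonyl sulfur gives a 5.0-fold lower number from compound 1 to compound 4 (0.70 log units; beyond the scatter) and so shows that this group can move the read-out beyond the usual scatter. The earlier compounds shown here offered no pair differing in one place, so they could not show this. No measurement shown accounts for the shift.

One step cannot tell whether losing the fluorine atoms or gaining the methyl groups matters more. On these data alone, how a plain phenyl ring, or a phenyl ring carrying an amine, would read at this place stays open.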